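The source may hold more compounds than are shown below. What is called first, only, known or untested is meant among the compounds shown, and "the series" means these compounds.

Working notes on the series. Going by the values given here, in a functional assay on L1210 cells (Mus musculus) for inhibition, read by cell counting, with a stated time of 48 h (on this read-out lower numbers stand for stronger inhibition and higher numbers for weaker inhibition), compound 1 (`CCN(CC)CN1C(=O)/C(=N/NC(=S)Nc2ccccc2)c2cc(Cl)ccc21`) gives 49000 nM, the higher of the two numbers so far, and compound 2 (`CCN(CC)CN1C(=O)/C(=N/NC(=S)Nc2ccccc2)c2ccccc21`) gives 13000 nM.

Compound 3 (`CCN(CC)CN1C(=O)/C(=N/NC(=S)Nc2ccc(Cl)cc2)c2cc(Cl)ccc21`) differs from compound 1 in one place: chloro in place of hydrogen on an aromatic carbon. This is chloro in place of hydrogen on an aromatic carbon, para to a large group, which turns phenyl into 4-chlorophenyl.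

Among the compounds with values here, only one measured step bears on this: a 3.8-fold lower number from compound 1 to compound 2 (0.58 log units; beyond the scatter), a modest change beyond the scatter. It removes a chloro from the shared core, not from the phenyl, so it shows that a chloro can matter in this series but offers weak guidance for the new place. Within the data shown here, no measured compound carries a substituent on the phenyl. A step of that modest size is therefore the outer limit of what is expected in this assay, and no firm direction can be given.

The expected result is no step beyond the scatter, with an estimated 1.2-fold lower number from compound 1 to compound 3 (0.09 log units; within the scatter). For compound 3 the estimated value is 40000 nM, within an expected range of 13000 nM to 100000 nM.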

Compound 3, half-maximal inhibitory concentration: > 125000 nM
Compound 3 ended at the assay's limit (the forecaster's own chance of this, stated with the estimate: 10%); middle value at least 3.1-fold (0.49 log units) away from the limit.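

Compound 3 stands at a limit of the assay, so its entry is not a number: the limit of > 125000 nM in this assay, at which 1 of the 3 values shown sits. Even so, the phenyl ring is not a silent place in this assay: an at least 2.5-fold higher number from compound 1 to compound 3 (0.40 log units; beyond the scatter), which makes 4-chlorophenyl in place of phenyl the first measured change on this ring and shows that it moves the read-out towards weaker inhibition, against the core of compound 1 that already carries a chloro. Read beside the other step, a 3.8-fold lower number from compound 1 to compound 2 (0.58 log units; beyond the scatter), chloro on the core and chloro on the phenyl now point the same way, with the compound carrying the extra chloro on the side of the higher number in both pairs; neither pair goes against this, although two pairs are a thin basis for a pattern.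

On these data alone, how far compound 3 lies past the limit remains open, so the true size of this step and its relation to the step on the core cannot be settled. As far as these compounds go, it is also open whether the loss belongs to chloro itself or would follow any group at this place, such as fluoro, methyl, methoxy or an amine.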